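The compounds below may be only part of what the source reports. "The series", "measured", "known", "first", "only" and "open" are said of these compounds alone.

Measured in a functional assay on HeLa cells (Homo sapiens) for antiproliferative activity, read by MTT assay, with a stated time of 72 h; on this read-out higher numbers stand for weaker inhibition and lower numbers for stronger inhibition:
Compound 1 `COc1ccc(N2CCN(C(=S)SCc3ccc4nc(N)nc(N)c4c3)CC2)cc1`: 1660 nM
Compound 2 `Nc1nc(N)c2cc(CSC(=S)N3CCN(c4ccccc4Cl)CC3)ccc2n1`: 4050 nM
Compound 3 `Nc1nc(N)c2cc(CSC(=S)N3CCN(c4ccccc4F)CC3)ccc2n1`: 6660 nM

In this assay, compound 3 at 6660 nM lies within the scatter of compound 2 at 4050 nM, so the two stand together at the weak end of the set. Compound 1 at 1660 nM is clearly stronger than both.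

Compound 4 `Nc1nc(N)c2cc(CSC(=S)N3CCN(c4ccccc4[N+](=O)[O-])CC3)ccc2n1` carries one change from compound 3: nitro in place of fluoro on an aromatic carbon. This is nitro in place of fluoro on an aromatic carbon, ortho to a large group, turning 2-fluorophenyl into 2-nitrophenyl.

Among the measured compounds shown here, the closest precedent is the exchange at this same place, a 1.6-fold higher number from compound 2 to compound 3 (0.22 log units; within the scatter), which did not exceed the scatter. The other two steps, a 2.4-fold higher number from compound 1 to compound 2 (0.39 log units; beyond the scatter) and a 4.0-fold higher number from compound 1 to compound 3 (0.60 log units; beyond the scatter), were modest, but each also replaces 4-methoxyphenyl, so they bear on this change only loosely. For the measured compounds named here, no measured compound carries a nitro group, which leaves the estimate wide. A step beyond the scatter is therefore not expected, and the expected change is small: a 1.4-fold lower number from compound 3 to compound 4 (0.14 log units; within the scatter). In this assay the estimated value for compound 4 is 4800 nM, with an expected range of 1800 nM to 12000 nM.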

Compound 4, half-maximal inhibitory concentration: 4880 nM
Estimate against measurement, compound 4: 1.0-fold (0.01 log units) below; low and high end bracket the measured number.
By their numbers in this assay, from the lowest: compound 1; then compounds 2, 4 and 3 (each within the scatter of the next).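

In this assay, the 2-nitrophenyl compound cannot be told apart from the 2-fluorophenyl and 2-chlorophenyl compounds (a 1.4-fold lower number from compound 3 to compound 4 (0.14 log units; within the scatter); a 1.2-fold higher number from compound 2 to compound 4 (0.08 log units; within the scatter)), even though three heavy atoms with two hydrogen-bond acceptors replace a single fluorine atom ortho to a large group. This place on the aromatic ring has so far tolerated fluoro, chloro and nitro with no step beyond the scatter, and the nitro compound also stays on the weaker side of the 4-methoxyphenyl compound (a 2.9-fold higher number from compound 1 to compound 4 (0.47 log units; beyond the scatter)), as the other two compounds do. No measurement here accounts for these results, so the reason for this flat response remains unknown.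

From the compounds shown here alone, whether the stronger result of compound 1 rests on the methoxy group itself or on where it sits on the ring stays open, as that step replaces the whole aryl group. It also remains to be seen whether an unsubstituted phenyl, an amine or a carboxylic acid at this same place would stay within the scatter of these three compounds or move the number beyond it.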